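The source may report more compounds than this note shows. Statements on the series, on what has been measured and on what is new or still open speak of the compounds shown alone.

Compound 1 `O=C(Nc1ccc(-c2ncccc2C(F)(F)F)cc1)c1ccc(C(F)(F)F)cc1` is the stronger of the two measured compounds: in a functional assay on CHO cells for antagonist activity at transient receptor potential cation channel subfamily V member 1 (Homo sapiens), read by FLIPR (a higher number here means a weaker inhibitor, a lower number a stronger inhibitor), compound 1 gives 24 nM. Compound 2 `O=C(Nc1ccc(-c2ccccn2)cc1)c1ccc(C(F)(F)F)cc1` differs from it only in that the trifluoromethyl on the pyridine ring is replaced by hydrogen, and in this assay compound 2 gives 1500 nM. Among the compounds with values here, that single change produced a 63-fold higher number from compound 1 to compound 2 (1.80 log units; beyond the scatter), so compound 2 holds the highest number of the two, with compound 1 as its only neighbour far below it.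

Compound 3 `Cc1cccnc1-c1ccc(NC(=O)c2ccc(C(F)(F)F)cc2)cc1` is not yet measured. Relative to compound 2 the change is methyl in place of hydrogen on an aromatic carbon, that is, a methyl placed on an aromatic carbon of the six-membered aromatic ring with one nitrogen, ortho to a large group, two atoms from the ring nitrogen; the same position that carries trifluoromethyl in compound 1. Within the data shown here, the only step that bears on this is the large one from compound 1 to compound 2, which removed a group from exactly this carbon. Putting a smaller group back there is expected to move the number downward again, though less far than the full step, and the expected step is a 10-fold lower number from compound 2 to compound 3 (1.00 log units; beyond the scatter). Compound 3 is therefore estimated at 150 nM, within a range of 40 nM to 600 nM.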

Compound 3, half-maximal inhibitory concentration: 160 nM
For compound 3 the middle estimate is 1.1-fold (0.03 log units) below the measured one, within the range that was stated.
By their numbers in this assay, from the lowest: compound 1; then compound 3; then compound 2.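

In this assay, placing just a methyl on this carbon, turning pyridin-2-yl into 3-methylpyridin-2-yl, gives a 9.4-fold lower number from compound 2 to compound 3 (0.97 log units; beyond the scatter). The large loss that came with removing trifluoromethyl can therefore be largely reversed without trifluoromethyl itself, by a group of only 1 heavy atom. The two groups are still not interchangeable, as swapping trifluoromethyl for methyl gives a 6.7-fold higher number from compound 1 to compound 3 (0.82 log units; beyond the scatter), so what matters here is which group sits on this carbon, not only whether something other than hydrogen does; nothing available explains why the two groups differ.

Still open, as far as these compounds go, is where a chlorine atom, a methoxy group or a longer chain such as ethyl on this same carbon would fall relative to compound 1 and compound 3. Also unknown is whether methyl would give a similar step on another carbon of the six-membered aromatic ring, since every comparison here concerns this one position.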